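Ring-widened lactam on the chain of compound 1

This account rests on a few compounds, and the source may have more. Where it says the series, first, only, none or still open, it means among the compounds named here.

Compound 1 `Cc1cc(C(=O)Nc2ccc(Cl)cc2)ccc1N(CCN1CCCC1=O)C(=O)Nc1ccc(Cl)cc1` stands second highest of the three compounds in an ADME assay on microsomes from liver (Homo sapiens) for metabolic stability (a lower number here means that the compound disappears faster, a higher number that the compound lasts longer), giving 0.158 h. Compound 2 `Cc1cc(C(=O)Nc2ccc(F)cn2)ccc1N(CCN1CCCC1=O)C(=O)Nc1ccc(Cl)cc1` gives 0.0667 h and compound 3 `Cc1cc(C(=O)Nc2ccc(Cl)cc2)ccc1N(CC(=O)N1CCOCC1)C(=O)Nc1ccc(Cl)cc1` gives 0.532 h; the steps read a 2.4-fold lower number from compound 1 to compound 2 (0.37 log units; beyond the scatter) and a 3.4-fold higher number from compound 1 to compound 3 (0.53 log units; beyond the scatter). Compound 4 `Cc1cc(C(=O)Nc2ccc(Cl)cc2)ccc1N(CCN1CCOCC1=O)C(=O)Nc1ccc(Cl)cc1` carries 3-oxomorpholin-4-yl in place of 2-oxopyrrolidin-1-yl on a saturated chain carbon, two bonds along the chain from an amide-type nitrogen. For the measured compounds named here, only the step to compound 3 bears on it, since it also reworks the chain end bearing the 2-oxopyrrolidin-1-yl group, though there the whole (2-oxopyrrolidin-1-yl)methyl was exchanged; the step to compound 2 touches an unrelated part. Trading one lactam ring for a six-membered ring with two hetero atoms is a smaller change, so in this assay a rise is expected that is modest at most, a 1.4-fold higher number from compound 1 to compound 4 (0.14 log units; within the scatter). Compound 4 is expected at 0.22 h, between 0.11 h and 0.45 h.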

Compound 4, half-life: 0.152 h
Estimate against measurement, compound 4: 1.4-fold (0.16 log units) above, and the stated range covers the measured number.
By their numbers in this assay, from the lowest: compound 2; then compounds 4 and 1 (each within the scatter of the next); then compound 3.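

In this assay the exchange of 2-oxopyrrolidin-1-yl for 3-oxomorpholin-4-yl on this chain leaves the number unchanged within the scatter (a 1.0-fold lower number from compound 1 to compound 4 (0.02 log units; within the scatter)). The higher number of compound 3 is not matched by this lactam (a 3.5-fold lower number from compound 3 to compound 4 (0.54 log units; beyond the scatter)), so a six-membered ring with 2 hetero atoms on the chain is not sufficient on its own to reach it. Nothing measured here accounts for this gap. Open, as far as these compounds go, is how a tertiary amine or a carboxylic acid at this chain end would read, and whether a longer chain would shift the number.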